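From 4-methoxycyclohexyl to cyclohexyl: a half-life estimate

The source may hold more compounds than are shown below. What is called first, only, known or untested is meant among the compounds shown, and "the series" means these compounds.

Compound 1 `Nc1ncnc2c1c(Oc1cc(C(F)(F)F)ccn1)nn2[C@H]1CC[C@@H](CO)CC1`: 1.6 h
Compound 2 `CO[C@H]1CC[C@H](n2nc(Oc3cc(C(F)(F)F)ccn3)c3c(N)ncnc32)CC1`: > 2.41 h

In an ADME assay on microsomes from liver (Homo sapiens) for metabolic stability, read by LC-MS, using NADPH, with a stated time of 10 min, tested at 10 uM (a higher number here means that the compound lasts longer, a lower number that the compound disappears faster), compound 2 stands at the limit of > 2.41 h in this assay, at which 1 of the 2 values shown sits, so its reading is a limit and not a number. Compound 3 `Nc1ncnc2c1c(Oc1cc(C(F)(F)F)ccn1)nn2C1CCCCC1` carries hydrogen in place of methoxy on a saturated ring carbon. Among the measured compounds shown here, the only measured step at this group is an at least 1.5-fold higher number from compound 1 to compound 2 (0.17 log units; that floor lies within the scatter). That step gives a floor and no size. Only a modest drop is therefore expected in this assay, leaving compound 3 close to compound 1 at 1.6 h. The expected step is an at least 1.4-fold lower number from compound 2 to compound 3 (0.15 log units; that floor lies within the scatter). For compound 3 the estimated half-life is 1.7 h, with an expected range from 0.7 h to 3.5 h.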

Compound 3, half-life: 0.55 h
Estimate against measurement, compound 3: 3.1-fold (0.49 log units) above; the measured number lies below the stated range.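

In this assay, a bare cyclohexyl ring turns out to be the shortest-lived of the three: hydrogen in place of methoxy gives an at least 4.3-fold lower number from compound 2 to compound 3 (0.64 log units; beyond the scatter), and hydrogen in place of hydroxymethyl gives a 2.9-fold lower number from compound 1 to compound 3 (0.46 log units; beyond the scatter). Among the compounds shown here, both oxygen-bearing groups on this saturated ring carbon therefore stand above hydrogen, which the earlier compounds could not show. The first step is only a floor, since the reading of compound 2 is a limit: the limit of > 2.41 h in this assay, at which 1 of the 3 values shown sits.

As far as these compounds go, whether methoxy truly exceeds hydroxymethyl stays open. So does whether a group without oxygen, such as methyl or an amine, would lengthen the half-life on this ring carbon as well.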